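A few compounds are considered here, and "the series" means these few. Any claim that something is new, unique, unknown or untested is made for them only; others in the source may bear on it.

In an assay on CHO cells for displacement of a labelled ligand from adenosine receptor A3 (Homo sapiens), tested at 10 uM (a higher number here means more inhibition at the concentration tested (going by the name of the read-out), a lower number less inhibition), two adenine nucleoside analogues have been measured. Compound 1, `CCNC(=O)OC[C@@H]1CO[C@@H](n2cnc3c(N)ncnc32)[C@@H]1O`, gives 8%. Compound 2, `Nc1ncnc2c1ncn2[C@@H]1OC[C@](O)(CO)[C@H]1O`, gives 35%. Among the two numbers compound 2 stands highest, and its nearest neighbour is compound 1, a number lower by a gap that lies beyond the usual scatter. These two compounds differ in more than one place, so their values are simply two points and nothing further is read into the gap between them.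

Compound 3, `Nc1ncnc2c1ncn2[C@@H]1OC[C@@H](CO)[C@H]1O`, has not yet been measured in this assay. It differs from compound 2 by one change: hydrogen in place of hydroxy on a saturated ring carbon. The single-point value of compound 2 in this assay, 35%, is the only anchor for what to expect, and the loss of one hydroxy group on a saturated ring carbon is a small structural change. A modest decrease is therefore expected, with a step of a number 13 percentage points lower from compound 2 to compound 3 (beyond the scatter) that may or may not reach beyond the scatter. Compound 3 is accordingly estimated to give 22% in this assay, within a range from 3% to 45%.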

Compound 3, a percentage reported as inhibition, at one concentration (the size of the read-out at that concentration, not a potency): 7%
Compound 3: middle estimate off by 15 percentage points, on the high side; the range from low to high includes it.
By their numbers in this assay, from the lowest: compounds 3 and 1 (each within the scatter of the next); then compound 2.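

In this assay, hydrogen in place of hydroxy on this saturated ring carbon, two ring bonds from the ring oxygen, gives a number 28 percentage points lower from compound 2 to compound 3 (beyond the scatter), so this single change, the only difference between the two compounds, accounts for the whole step and the hydroxy at this position counts for the reading. The second comparison concerns another place: hydrogen in place of ethylcarbamoyl on an oxygen on a saturated carbon gives a number 1 percentage points lower from compound 1 to compound 3 (within the scatter), so in the absence of the ring hydroxy, this carbamate group and the free hydroxy of compound 3 cannot be told apart at the single concentration tested. Nothing available explains why the ring hydroxy matters here.

The compounds shown leave open whether the step belongs to hydroxy itself or whether another group on the same ring carbon, such as an amine, a methoxy group or a fluorine atom, would keep the reading of compound 2. Among these compounds, they also leave open what an ethylcarbamoyl group on the oxygen would do with the ring hydroxy present, since the two changes appear together in no compound here.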